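Changing One Aromatic Group on a Shared Core

The compounds below may be only part of what the source reports. "The series", "measured", "known", "first", "only" and "open" are said of these compounds alone.

Three compounds share one core and differ only in the group attached to one aromatic carbon. In a functional assay on BJAB cells (Homo sapiens) for antiproliferative activity, with a stated time of 4 days (on this read-out lower numbers stand for an effect already at smaller amounts and higher numbers for an effect only at larger amounts of compound), compound 1 `Cc1nn(-c2nc(-c3ccc(Cl)c(Cl)c3)c(SC(C)C)s2)c(C(=O)O)c1-c1cnccn1` gives 14000 nM, compound 2 `CC(=O)Nc1ccc(-c2c(C)nn(-c3nc(-c4ccc(Cl)c(Cl)c4)c(SC(C)C)s3)c2C(=O)O)cc1` gives 139000 nM, and compound 3 `COc1cc(Cl)cc(-c2c(C)nn(-c3nc(-c4ccc(Cl)c(Cl)c4)c(SC(C)C)s3)c2C(=O)O)c1` gives 760 nM, the lowest of the three. The two earlier swaps at this position gave an 18-fold lower number from compound 1 to compound 3 (1.27 log units; beyond the scatter) and a 180-fold lower number from compound 2 to compound 3 (2.26 log units; beyond the scatter). Compound 4 `CNc1cc(-c2c(C)nn(-c3nc(-c4ccc(Cl)c(Cl)c4)c(SC(C)C)s3)c2C(=O)O)ccn1` carries yet another group there: 2-(methylamino)pyridin-4-yl in place of 3-chloro-5-methoxyphenyl on an aromatic carbon. Both earlier swaps moved the number far, so a large move is expected again, this time upward, estimated as a 26-fold higher number from compound 3 to compound 4 (1.42 log units; beyond the scatter). For compound 4 the expected value in this assay is therefore 20000 nM, within a range from 4000 nM to 100000 nM.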

Compound 4, half-maximal effective concentration: 18000 nM
Compound 4: middle estimate off by 1.1-fold (0.05 log units), on the high side; low and high end bracket the measured number.
By their numbers in this assay, from the lowest: compound 3; then compounds 1 and 4 (each within the scatter of the next); then compound 2.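

The 2-(methylamino)pyridin-4-yl group gives a 24-fold higher number from compound 3 to compound 4 (1.37 log units; beyond the scatter) and so does not keep the low number of the 3-chloro-5-methoxyphenyl group. It still gives a 7.7-fold lower number from compound 2 to compound 4 (0.89 log units; beyond the scatter) and so is clearly better tolerated at this position than the 4-acetamidophenyl group. The step of a 1.3-fold higher number from compound 1 to compound 4 (0.11 log units; within the scatter) lies within the scatter, so this group and pyrazin-2-yl cannot be told apart here, although they differ in both ring and substituent.

Nothing available explains these differences. From the compounds shown here alone, it also remains open which part of compound 3's group matters: a phenyl ring carrying only the chlorine or only the methoxy would separate the two.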